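Extending the Ethylamino Chain of Compound 3

A few compounds are considered here, and "the series" means these few. Any claim that something is new, unique, unknown or untested is made for them only; others in the source may bear on it.

Compound 3 `CCNc1nc(-c2ccccc2)nc2c1nnn2Cc1ccccc1F` gives the lowest number of the three measured compounds in an assay on Cerebral cortex for displacement of a labelled ligand from adenosine receptor A1 (Bos taurus) (on this read-out lower numbers stand for stronger inhibition and higher numbers for weaker inhibition), with 11 nM. Compound 1 `CCNc1nc(-c2ccccc2)nc2c1nnn2Cc1ccccc1` gives 91 nM in this assay, and compound 2 `CCNc1nc(-c2ccccc2)nc2c1nnn2Cc1ccccc1Cl` gives 463 nM. The steps among them all change a halogen on an aromatic carbon: an 8.3-fold lower number from compound 1 to compound 3 (0.92 log units; beyond the scatter), a 5.1-fold higher number from compound 1 to compound 2 (0.71 log units; beyond the scatter) and a 42-fold lower number from compound 2 to compound 3 (1.62 log units; beyond the scatter). Compound 4 `CCCNc1nc(-c2ccccc2)nc2c1nnn2Cc1ccccc1F` keeps the fluoro of compound 3 and differs from it only in one place: methyl in place of hydrogen on a saturated chain carbon, two bonds along the chain from a nitrogen on an aromatic ring. None of the three measured steps touches this part of the structure, so they give no direct guide to the size or direction of the step to compound 4 in this assay. With nothing to show a change, compound 4 is expected to stay close to compound 3, a step of a 1.1-fold higher number from compound 3 to compound 4 (0.04 log units; within the scatter) that should remain within the usual scatter. The estimate for compound 4 in this assay is therefore 12 nM, within the range 4 nM to 40 nM.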

Compound 4, inhibition constant: 3.2 nM
Compound 4: middle estimate off by 3.8-fold (0.57 log units), on the high side; measured number outside the range, below it.
By their numbers in this assay, from the lowest: compound 4; then compound 3; then compound 1; then compound 2.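

Ethylamino to propylamino gives a 3.4-fold lower number from compound 3 to compound 4 (0.54 log units; beyond the scatter) in this assay, so this chain position, untouched by the halogen steps, is not silent. Methyl in place of hydrogen on a saturated chain carbon, two bonds along the chain from a nitrogen on an aromatic ring, moves the number in the lower direction, and the chain takes this extra carbon with no loss in this assay. Nothing available explains why the added methyl has this effect.

From the compounds shown here alone, it remains open whether a butyl group or a longer chain would carry the change further, and how a branched isopropyl group or a cyclopropyl ring would compare. Also open, going by these compounds, is whether propylamino in place of ethylamino would do the same with hydrogen or chloro in place of the fluoro, as in compound 1 and compound 2.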